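This account rests on a few compounds, and the source may have more. Where it says the series, first, only, none or still open, it means among the compounds named here.

Of the compounds shown here, three of one family have been tested in a functional assay on NCI-H226 cells (Homo sapiens) for inhibition (on this read-out lower numbers stand for stronger inhibition of growth and higher numbers for weaker inhibition of growth), and a fourth awaits its turn. Compound 1 `Nc1ccc(-c2nc3ccc(F)cc3s2)cc1I` carries an iodo group, and compound 2 `Nc1ccc(-c2nc3ccc(F)cc3s2)cc1Cl` carries a chloro group in the same position on the same core. In this assay compound 1 gives 70 nM, while compound 2 gives 14100 nM. The change between them is iodo in place of chloro on an aromatic carbon, and it produced a 200-fold lower number from compound 2 to compound 1 (2.30 log units; beyond the scatter).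

Compound 3 `Nc1ccc(-c2nc3cc(F)ccc3s2)cc1Cl` has the chloro group but sits on a core whose atoms are joined differently from those of compound 2; the difference between the two cores is not broken down here. In this assay, for the measured compounds named here, compound 3 gives 30 nM, the lowest of the three numbers so far.

Compound 4 `Nc1ccc(-c2nc3cc(F)ccc3s2)cc1I` is the not yet measured partner of compound 3: the change from compound 3 to compound 4 is iodo in place of chloro on an aromatic carbon, the same change as from compound 2 to compound 1, placed in the same surroundings. On the first core that change gave a very large step. Because compound 3 already reaches 30 nM, the room for a step of the same size is narrower, and a single earlier example is a thin basis. For compound 4 in this assay a step of a 5.0-fold lower number from compound 3 to compound 4 (0.70 log units; beyond the scatter) is expected. The expected value for compound 4 is 6 nM, most likely between 0.5 nM and 40 nM.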

Compound 4, concentration for 50% growth inhibition: 10200 nM
Compound 4: middle estimate off by 1700-fold (3.23 log units), on the low side; measured number above the stated range.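

In this assay, putting iodo in place of chloro on an aromatic carbon of the core of compound 3 gave a 340-fold higher number from compound 3 to compound 4 (2.53 log units; beyond the scatter), so the swap that strongly lowered the number on one core strongly raised it on the other. Set side by side, the two results run in opposite directions, and the gap is far too large to be scatter: the same change on two cores in this assay, a 200-fold lower number (2.30 log units; beyond the scatter) from compound 2 to compound 1 and a 340-fold higher number (2.53 log units; beyond the scatter) from compound 3 to compound 4, 68000-fold (4.84 log units) apart, beyond the scatter of two such steps. For the compounds shown here, this shows that the result of this swap cannot simply be carried from one core to the other, even though the swap itself is the same on both, but with only two pairs it does not show why the cores respond differently, nor does it give a rule for any further core.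

The compounds shown leave open how other groups in the same place would behave on each core, for example a bromo group, a methyl group or a nitrile. They also leave open what happens on a core with no fluoro group at all, or with a methoxy group in its stead, which could help show how much the core itself decides the outcome of the swap.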